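Chloro to methyl swap on the aryl piperazine

The compounds below may be only part of what the source reports. "The series", "measured", "known", "first", "only" and "open" are said of these compounds alone.

Measured in an assay on HEK293 cells for inhibition of Voltage-dependent T-type calcium channel subunit alpha-1G (Homo sapiens), read by patch clamp; on this read-out lower numbers stand for stronger inhibition and higher numbers for weaker inhibition:
compound 1 `CCCc1nc(-c2ccccc2)c(CNCCCN2CCN(c3cccc(Cl)c3)CC2)o1` gives 1750 nM
compound 2 `CCCc1nc(-c2ccccc2)c(CNCCN2CCN(c3cccc(F)c3)CC2)o1` gives 3350 nM

Compound 1 carries the lower of the two numbers, but compound 2 lies within the usual scatter of it, so the pair is not separated. Compound 3 `CCCc1nc(-c2ccccc2)c(CNCCCN2CCN(c3cccc(C)c3)CC2)o1` differs from compound 1 by methyl in place of chloro on an aromatic carbon. Within the data shown here, no measured step of this kind exists, so the expectation rests on compound 1 alone. The expected step is a 1.4-fold higher number from compound 1 to compound 3 (0.15 log units; within the scatter), a change not beyond the scatter, with no clear direction. Compound 3 is therefore estimated at 2500 nM, within a range of 1000 nM to 6500 nM.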

Compound 3, half-maximal inhibitory concentration: 1190 nM
Beside the measured number, compound 3's estimate is 2.1-fold (0.32 log units) above it; measured number inside the range.
By their numbers in this assay, from the lowest: compounds 3, 1 and 2 (each within the scatter of the next, the first and the last beyond it).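

In this assay, among these compounds, the exchange of 3-chlorophenyl to 3-methylphenyl gives a 1.5-fold lower number from compound 1 to compound 3 (0.17 log units; within the scatter), the first step read at this position. On this aromatic carbon, methyl and chloro are therefore not separated, so the two groups cannot be ranked here. Nothing measured on these compounds bears on the reason for this result.

From the compounds shown here alone, whether trifluoromethyl, methoxy or an amine on this aromatic carbon would separate from chloro and methyl remains open. Also open, going by these compounds, is whether methyl and chloro would read alike on the chain of compound 2.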